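The compounds below may be only part of what the source reports. "The series", "measured", "known", "first", "only" and "open" are said of these compounds alone.

Working notes on the series. Compound 1 `COc1ccc(C(=O)Nc2ncc(Cc3cccc(F)c3)s2)cc1OCCO` gives 2 nM in an assay on microsomes for inhibition of acyl-CoA desaturase 1 (Mus musculus), with a stated time of 60 min; a lower number here means a stronger inhibitor, a higher number a weaker inhibitor. Among the compounds with values here, compound 2 `COc1ccc(C(=O)Nc2ncc(Cc3cccc(C(C)(C)C)c3)s2)cc1OCCO` gives 1310 nM in this assay and so stands with the highest number of the two measured so far; its nearest neighbour is compound 1. Within the data shown here, the only measured step is a 660-fold higher number from compound 1 to compound 2 (2.82 log units; beyond the scatter), a large change from a small halogen to a bulky branched alkyl group on the pendant aromatic ring.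

Compound 3 `COc1ccc(C(=O)Nc2ncc(Cc3ccc(Cl)c(Cl)c3)s2)cc1OCCO` has not yet been measured. Compared with compound 2 the change is 3,4-dichlorophenyl in place of 3-(tert-butyl)phenyl on a saturated chain carbon bound to an aromatic carbon. This removes the tert-butyl that goes with the large step of a 660-fold higher number from compound 1 to compound 2 (2.82 log units; beyond the scatter) and returns to halogen substitution on that ring, as in compound 1, though now with two chlorines rather than one fluoro. On that basis the number for compound 3 is expected to fall well below that of compound 2, with the step of an 87-fold lower number from compound 2 to compound 3 (1.94 log units; beyond the scatter) expected to be large and in the lowering direction. The estimate for compound 3 in this assay is 15 nM, with an expected range from 3 nM to 80 nM.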

Compound 3, half-maximal inhibitory concentration: 0.8 nM
The estimate for compound 3 lay 19-fold (1.27 log units) above the measured number; the whole stated range lies above it.
By their numbers in this assay, from the lowest: compound 3; then compound 1; then compound 2.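

With a change at this one place, this assay gives a 1600-fold lower number from compound 2 to compound 3 (3.21 log units; beyond the scatter), while a 2.5-fold lower number from compound 1 to compound 3 (0.40 log units; beyond the scatter) shows that compound 1 did not mark the lowest number reachable on the saturated chain carbon bound to an aromatic carbon. Within the data shown here, compound 3 now has the lowest number of the three, and within this set the two low numbers go with halogen-bearing groups and the one high number with 3-(tert-butyl)phenyl, a pattern that rests on these three compounds alone and has no compound against it. Nothing available explains why the numbers differ so widely at this place.

On these data alone, it remains open whether a halogen is needed at all, since a methoxy group, a nitrile or plain phenyl at this place could equally give a low number, and whether the two chlorines both contribute, which 3-chlorophenyl and 4-chlorophenyl would separate. As far as these compounds go, the rest of the structure is shared by all three compounds, so how an amine or a carboxylic acid elsewhere on the shared core would alter these numbers also stays unknown.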